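Aryl urea piperidines as CXCR3 antagonists: an ester variant

A few compounds are considered here, and "the series" means these few. Any claim that something is new, unique, unknown or untested is made for them only; others in the source may bear on it.

Compound 1: `O=C(Nc1ccc2ccccc2c1)NC1CCN(C/C2=C/CCCCCC2)CC1`, 110 nM
Compound 2: `O=C(Nc1cccc(OC(F)(F)F)c1)NC1CCN(C/C2=C/CCCCCC2)CC1`, 104 nM
Compound 3: `O=C(Nc1c(Cl)cncc1Cl)NC1CCN(C/C2=C/CCCCCC2)CC1`, 3400 nM

In a functional assay on CHO cells for antagonist activity at C-X-C chemokine receptor type 3 (Homo sapiens), read by GTPgammaS binding (a lower number here means a stronger inhibitor, a higher number a weaker inhibitor), compound 2 gives the lowest of the three numbers. Compound 1, with a fused aromatic ring on the urea, sits within the scatter of compound 2, so the two cannot be ordered. Compound 3, which carries the dichlorinated pyridine, stands far beyond the scatter with a much higher number.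

Compound 4, `COC(=O)c1cccc(NC(=O)NC2CCN(C/C3=C/CCCCCC3)CC2)c1`, keeps the shared core and differs from compound 2 only by methoxycarbonyl in place of trifluoromethoxy on an aromatic carbon. Within the data shown here, no step between two measured compounds isolates this change, so the account can rest only on the values of compounds 1 and 2, which show that two different aryl groups give similar numbers in this assay. A modest upward step, near the edge of the scatter, is expected a 2.4-fold higher number from compound 2 to compound 4 (0.38 log units; beyond the scatter). Compound 4 is estimated at 250 nM, in the range 80 nM to 900 nM.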

Compound 4, inhibition constant: 660 nM
Compound 4: middle estimate off by 2.6-fold (0.42 log units), on the low side; low and high end bracket the measured number.
By their numbers in this assay, from the lowest: compounds 2 and 1 (each within the scatter of the next); then compound 4; then compound 3.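

In this assay, methoxycarbonyl in place of trifluoromethoxy on an aromatic carbon, meta to a large group, gives a 6.3-fold higher number from compound 2 to compound 4 (0.80 log units; beyond the scatter), the first change in one place alone among these compounds. The number at this position therefore depends on which group it carries, and this exchange moves it beyond the scatter. Nothing given here accounts for the rise, so no reason for it can be offered. Still open, from the compounds shown here alone, is how a carboxylic acid, a primary amide or an ethyl ester at this same place would compare with compound 4.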